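Swapping Bromo for Methoxy in a Thioether Series

This account rests on a few compounds, and the source may have more. Where it says the series, first, only, none or still open, it means among the compounds named here.

Of the compounds shown here, three built on one shared core have been tested in an assay on microsomes for inhibition of Amine oxidase [flavin-containing] B (Homo sapiens), read by fluorescence and spectrophotometry, with a stated time of 20 min; on this read-out higher numbers stand for weaker inhibition and lower numbers for stronger inhibition. Compound 1 `Cn1c(=O)c2c(nc(SCCc3ccc(Br)cc3)n2C)n(C)c1=O` gives 19 nM. Compound 2 `Cc1ccc(CCSc2nc3c(c(=O)n(C)c(=O)n3C)n2C)cc1` gives 72 nM, and compound 3 `Cn1c(=O)c2c(nc(SCCc3cccc(Br)c3)n2C)n(C)c1=O` gives 40 nM. Among these three numbers compound 3 stands second highest: its gap to compound 2 is within the scatter, while the step of a 2.1-fold higher number from compound 1 to compound 3 (0.32 log units; beyond the scatter) lies beyond it.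

Compound 4 `COc1cccc(CCSc2nc3c(c(=O)n(C)c(=O)n3C)n2C)c1` has not yet been measured. It differs from compound 3 in one place: methoxy in place of bromo on an aromatic carbon. Going by the values given here, no measured pair swaps bromo for methoxy, so the closest guide is the step of a 3.8-fold higher number from compound 1 to compound 2 (0.58 log units; beyond the scatter), where bromo gave way to methyl on the ring. The step of a 2.1-fold higher number from compound 1 to compound 3 (0.32 log units; beyond the scatter) shows that relocating the bromo shifted the number only modestly, and a 1.8-fold lower number from compound 2 to compound 3 (0.26 log units; within the scatter) stays within the scatter. On this basis a modest weakening, or possibly no change beyond the scatter, is expected in this assay. The expected step is a 2.3-fold higher number from compound 3 to compound 4 (0.35 log units; beyond the scatter). Compound 4 is therefore estimated at 90 nM, with a likely range from 35 nM to 230 nM.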

Compound 4, half-maximal inhibitory concentration: 125 nM
Compound 4: middle estimate off by 1.4-fold (0.14 log units), on the low side; measured number inside the range.
By their numbers in this assay, from the lowest: compound 1; then compounds 3, 2 and 4 (each within the scatter of the next, the first and the last beyond it).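

In this assay, going by these compounds alone, the only direct swap of bromo for methoxy, on an aromatic carbon meta to a large group, gives a 3.1-fold higher number from compound 3 to compound 4 (0.49 log units; beyond the scatter), so at this position the change from 3-bromophenyl to 3-methoxyphenyl costs inhibition by more than the usual scatter. The comparison with the 4-methylphenyl group gives a 1.7-fold higher number from compound 2 to compound 4 (0.24 log units; within the scatter), which lies within the scatter and so does not separate these two compounds, while the comparison with the 4-bromophenyl group gives a 6.6-fold higher number from compound 1 to compound 4 (0.82 log units; beyond the scatter), the widest step in this set. No independent data here bear on the reason for these steps.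

The compounds shown leave open how methoxy would behave at the ring position that holds bromo in compound 1, which would show whether the group or its place matters more. Also open, on these data alone, is whether chloro, fluoro or an amine on the same aromatic carbon would stay close to compound 3 or give a number closer to that of compound 4.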